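Methyl on the phenol oxygen of compound 1

The compounds below may be only part of what the source reports. "The series", "measured", "known", "first", "only" and "open" are said of these compounds alone.

Compound 1 `O=C(Nc1cccc(-n2cc(-c3ccncc3)c(-c3cc(O)cc(Cl)c3)n2)c1)Nc1ccc(Cl)c(C(F)(F)F)c1` was tested in a functional assay on A498 cells (Homo sapiens) for inhibition, read by sulforhodamine B assay, with a stated time of 48 h, tested at 0.1 uM (a lower number here means a stronger effect, a higher number a weaker effect of the compound at the concentration tested), where compound 1 gives 50%. Among the measured compounds shown here, of the two numbers in hand this is the lowest; its nearest neighbour is compound 2 `O=C(Nc1cccc(-n2cc(-c3ccncc3)c(-c3cc(O)cc(Cl)c3)n2)c1)Nc1ccc(Cl)c(Cl)c1`, which in this assay gives 94%, and the single step that joins the two, chloro in place of trifluoromethyl on an aromatic carbon, reads a number 44 percentage points higher from compound 1 to compound 2 (beyond the scatter), a change beyond the scatter.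

Compound 3 `COc1cc(Cl)cc(-c2nn(-c3cccc(NC(=O)Nc4ccc(Cl)c(C(F)(F)F)c4)c3)cc2-c2ccncc2)c1` has not yet been measured in this assay. It differs from compound 1 by methyl in place of hydrogen on an oxygen on an aromatic ring. Cut one bond further out, the change reads hydroxy to methoxy, 3-chloro-5-hydroxyphenyl to 3-chloro-5-methoxyphenyl. For the measured compounds named here, no measured step touches this oxygen: the one step in hand concerns a different aromatic carbon, so it gives no direct guide to the present change, and the expectation can only be loose. The number for compound 3 in this assay is estimated at 70%, with a range from 40% to 100%. The step this estimate implies, a number 20 percentage points higher from compound 1 to compound 3 (beyond the scatter), is expected to be a weakening that may reach beyond the scatter.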

Compound 3, a percentage reported as activity, at one concentration (the size of the read-out at that concentration, not a potency): 59%
Estimate against measurement, compound 3: 11 percentage points above; low and high end bracket the measured number.
By their numbers in this assay, from the lowest: compounds 1 and 3 (each within the scatter of the next); then compound 2.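

In this assay, putting methyl on the oxygen of the 3-chloro-5-hydroxyphenyl group gives a number 9 percentage points higher from compound 1 to compound 3 (within the scatter) and so stays inside the usual scatter. Among the compounds shown here, the hydrogen on this oxygen can therefore be replaced by methyl without a change that can be told apart from repeat measurements at the concentration tested, which is a first reading at a position the earlier pair did not touch. The other listed step, a number 44 percentage points higher from compound 1 to compound 2 (beyond the scatter) with chloro in place of trifluoromethyl on an aromatic carbon, is printed as beyond the scatter, so within this small set a clear change is seen on that aromatic carbon and none on the oxygen. Nothing in hand offers an explanation for this result.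

What the compounds shown leave open is whether the oxygen would accept more than a single methyl, for instance an ethyl group, a longer chain or a chain ending in an amine. On these data alone, it also remains open whether methyl on this oxygen would read the same way in the chloro series of compound 2, where the number is already much higher.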